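The source may hold more compounds than are shown below. What is called first, only, known or untested is meant among the compounds shown, and "the series" means these compounds.

Measured so far: compound 1 `OCCCC(F)F` with 0.29, compound 2 `CCCC(F)(F)CO` with 1.25, and compound 3 `OCCC(F)C(F)F` with 0.29.

All three were characterised in a physicochemical assay for lipophilicity, read by NMR; a lower number here means a more polar compound, a higher number a more lipophilic compound. Compound 2 stands highest of the three numbers, beyond the scatter from both compound 1 and compound 3, which lie far below it. Compound 3 and compound 1 differ in one place, (hydrogen in place of fluoro on a saturated chain carbon bound to two saturated chain carbons), and the step of no change at the digits printed from compound 3 to compound 1 (within the scatter) shows that this change left the read-out where it was. How the core of compound 2 differs from the core of compound 3 is not broken down here.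

Compound 4 `CCCC(F)CO` has not yet been measured. It derives from compound 2 through (hydrogen in place of fluoro on a saturated chain carbon bound to a fluorine atom and two saturated chain carbons). Among the measured compounds shown here, this is the same kind of change as the one from compound 3 to compound 1, but not the same: in compound 2 the carbon that loses its fluoro is bound to a fluorine atom as well as to two saturated chain carbons, whereas in compound 3 it is bound to two saturated chain carbons only. For the measured compounds named here, the one measured example of this kind of change, no change at the digits printed from compound 3 to compound 1 (within the scatter), gives no reason to expect a large shift, yet the surroundings of the place differ, so the earlier step is only a loose guide. In this assay the step from compound 2 to compound 4 is expected to be a number 0.35 log units lower from compound 2 to compound 4 (beyond the scatter), a modest fall that rests on compound 2 sitting at 1.25 and on the step of no change at the digits printed from compound 3 to compound 1 (within the scatter) being flat. For compound 4 the estimate in this assay is 0.9, most likely between 0.55 and 1.2.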

Compound 4, partition coefficient: 0.87
The estimate for compound 4 lay 0.03 log units above the measured number; the range from low to high includes it.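

In this assay, the replacement of fluoro by hydrogen gave a number 0.38 log units lower from compound 2 to compound 4 (beyond the scatter), whereas the earlier example of the same kind of change gave no change at the digits printed from compound 3 to compound 1 (within the scatter), so the replacement did not give the same result on both cores. This shows that a flat result on one core could not simply be carried over to the other, but with one step on each core it does not show how the change would behave on any further core, and the two steps differ both in their core and in the carbon that loses its fluoro, which in compound 2 is bound to a fluorine atom and two saturated chain carbons and in compound 3 to two saturated chain carbons only, so the pair cannot separate these two differences. No measurement is at hand that explains why the two steps differ.

The compounds shown leave open whether the replacement would stay flat or bring a fall on a longer chain, or on a core carrying an amine or a carboxylic acid. They also leave open how the same change would read in any measurement other than this assay.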